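A few compounds are considered here, and "the series" means these few. Any claim that something is new, unique, unknown or untested is made for them only; others in the source may bear on it.

Going by the values given here, compound 2 `Cc1nc(S(C)(=O)=O)ccc1Oc1ncnc(OC2CCN(C(=O)O[C@H](C)CF)CC2)c1F` gives 79% in a functional assay on isolated protein for inhibition of Glucose-dependent insulinotropic receptor (Rattus norvegicus), read by HTRF and cAMP accumulation (a higher number here means a larger maximal response, a lower number a smaller maximal response), the lower of the two numbers measured so far. Compound 1 `Cc1nc(S(C)(=O)=O)ccc1Oc1ncnc(OC2CCN(C(=O)OC(C)(C)CF)CC2)c1F` gives 95% in this assay, separated from it by the step of a number 16 percentage points lower from compound 1 to compound 2 (beyond the scatter). Compound 3 `Cc1nc(S(C)(=O)=O)ccc1Oc1ncnc(OC2CCN(C(=O)OC3(C(F)(F)F)COC3)CC2)c1F` carries a further change at that same place: 3-(trifluoromethyl)oxetan-3-yl in place of 1-(fluoromethyl)ethyl on an oxygen next to a carbonyl group. Among the compounds with values here, the only comparable step is a number 16 percentage points lower from compound 1 to compound 2 (beyond the scatter), likewise a replacement of the group on this oxygen. A second replacement there could move the number either way, so only a small step, not clearly beyond the scatter, is expected. Compound 3 is estimated at 86%, with a range from 68% to 104%. That expectation means a step of a number 7 percentage points higher from compound 2 to compound 3 (within the scatter).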

Compound 3, largest response reached (reported as efficacy), in percent of the reference or control that the assay uses: 84%
Compound 3: middle estimate off by 2 percentage points, on the high side; the measured number falls inside the stated range.
By their numbers in this assay, from the lowest: compounds 2 and 3 (each within the scatter of the next); then compound 1.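

In this assay, the 3-(trifluoromethyl)oxetan-3-yl group, with its four-membered ring and more heavy atoms, gives no clear change from the smaller 1-(fluoromethyl)ethyl group (a number 5 percentage points higher from compound 2 to compound 3 (within the scatter)). So on this oxygen, a larger ring-bearing group can keep the response within the scatter of compound 2. It still does not match the 1-(fluoromethyl)-1-methylethyl group (a number 11 percentage points lower from compound 1 to compound 3 (beyond the scatter)), and nothing measured here gives a reason for these differences. On these data alone, it remains open how an oxetan-3-yl group without the trifluoromethyl, or a chain carrying an amine, would read at this place.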